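Methoxy addition on an aryl ring: working notes

The compounds below may be only part of what the source reports. "The series", "measured", "known", "first", "only" and "open" are said of these compounds alone.

Measured compounds:
compound 1, `COc1cc(-c2cc(/C=C/C(=O)c3ccc(N)cc3)[nH]n2)cc(OC)c1OC`, in a functional assay on HCC 2998 cells (Homo sapiens) for cytotoxicity, read by sulforhodamine B assay, with a stated time of 48 h, tested at 10 uM (on this read-out higher numbers stand for a weaker effect at the one concentration tested and lower numbers for a stronger effect), gives -86%
compound 2, `COc1ccc(C(=O)/C=C/c2cc(-c3cc(OC)c(OC)c(OC)c3)n[nH]2)cc1OC`, in this assay gives -85%
compound 3, `COc1ccc(-c2cc(/C=C/C(=O)c3ccc(N)cc3)[nH]n2)cc1OC`, in this assay gives -75%

Compound 3 and compound 1 differ in one place, (methoxy in place of hydrogen on an aromatic carbon), and the step is a number 11 percentage points lower from compound 3 to compound 1 (beyond the scatter). Compound 1 and compound 2 differ on the carbonyl carbon, and the step is a number 1 percentage points higher from compound 1 to compound 2 (within the scatter). The difference between the cores of compound 2 and compound 3 is not broken down here; their values lie within the scatter of each other.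

Compound 4, `COc1cc(C(=O)/C=C/c2cc(-c3cc(OC)c(OC)c(OC)c3)n[nH]2)cc(OC)c1OC`, is not yet measured. It differs from compound 2 by methoxy in place of hydrogen on an aromatic carbon, the same change as that from compound 3 to compound 1, made at the same place. The expected step in this assay is a number 5 percentage points lower from compound 2 to compound 4 (within the scatter), close to the earlier a number 11 percentage points lower from compound 3 to compound 1 (beyond the scatter), because compound 1 gives -86% after the same change. Because compound 2 already gives -85%, little downward room remains on this read-out, so compound 4 is expected at about -90%, estimated between -100% and -78%. This rests on a single earlier instance of the change.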

Compound 4, a percentage reported as activity, at one concentration (the size of the read-out at that concentration, not a potency): -87%
Compound 4: the middle estimate sits 3 percentage points below what was measured; the range from low to high includes it.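

In this assay, adding the methoxy group to the core of compound 2 gives a number 2 percentage points lower from compound 2 to compound 4 (within the scatter). Set beside the earlier instance, the step shows no measurable difference between the two cores: the same change on two cores in this assay, a number 11 percentage points lower (beyond the scatter) from compound 3 to compound 1 and a number 2 percentage points lower (within the scatter) from compound 2 to compound 4, 9 percentage points apart, within the scatter of two such steps. This is compatible with the change carrying over from one core to the other, but it does not fix a size for the change or show that the two steps are the same, as only two instances exist, one of them lies within the scatter, and both come from a single concentration on a single cell line.

The compounds shown leave open whether the step would hold on cores that give a weaker effect in this assay. Also open, on these data alone, is what an ethoxy group, a chlorine atom or an amine would do in place of this methoxy, on an aromatic carbon of the same ring.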